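Methyl on the ring-bound phenyl of compound 2

The source may report more compounds than this note shows. Statements on the series, on what has been measured and on what is new or still open speak of the compounds shown alone.

Compound 1, `COc1c(F)cccc1N1C(=O)CSC1c1cccc(C(=O)NCCCCc2ccccc2)c1`: 0%
Compound 2, `O=C(NCCCCc1ccccc1)c1cccc(C2SCC(=O)N2c2ccccc2)c1`: 89%

In a functional assay on MG-63 cells (Homo sapiens) for inhibition, read by CCK-8 assay, with a stated time of 72 h, tested at 1 uM (a higher number here means more inhibition at the concentration tested (going by the name of the read-out), a lower number less inhibition), compound 1 gives 0%, and compound 2 gives 89%. Among the measured compounds shown here, of the two compounds measured, compound 2 stands highest; the only other number, that of compound 1, lies far beneath it, and the single recorded step, a number 89 percentage points higher from compound 1 to compound 2 (beyond the scatter), is the whole of what is known.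

Compound 3, `Cc1cccc(N2C(=O)CSC2c2cccc(C(=O)NCCCCc3ccccc3)c2)c1`, has not yet been measured. It differs from compound 2 by methyl in place of hydrogen on an aromatic carbon. For the measured compounds named here, the one measured step bears on it only loosely: it shows that the substituted aryl group of compound 1 loses all activity against the plain phenyl of compound 2, but that change was a different pair of groups at a different place, so it says little about a lone methyl. Because the drop from compound 1 to compound 2 was a number 89 percentage points higher from compound 1 to compound 2 (beyond the scatter), some caution about decorating this ring seems warranted, and a modest downward step, a number 19 percentage points lower from compound 2 to compound 3 (beyond the scatter), is expected. Compound 3 is therefore estimated at 70%, within a range from 30% to 95%.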

Compound 3, a percentage reported as inhibition, at one concentration (the size of the read-out at that concentration, not a potency): 93%
The estimate for compound 3 lay 23 percentage points below the measured number; the measured number falls inside the stated range.
By their numbers in this assay, from the lowest: compound 1; then compounds 2 and 3 (each within the scatter of the next).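

In this assay, the methyl on the aromatic carbon, meta to a large group, is accepted on this ring: the change from phenyl to 3-methylphenyl gives a number 4 percentage points higher from compound 2 to compound 3 (within the scatter), so the two compounds cannot be told apart. Against the 3-fluoro-2-methoxyphenyl group, the 3-methylphenyl group gives a number 93 percentage points higher from compound 1 to compound 3 (beyond the scatter), which shows that a substituent on this ring does not in itself abolish the read-out, with compound 1 the one case among the three where a substituted ring gives no inhibition. Nothing available accounts for this contrast between the two substituted rings.

The compounds shown leave open whether the methoxy group or the fluorine of compound 1 goes with its lack of inhibition, as the two appear only together, and whether either alone on this ring would give the same result. They also leave open whether something other than a methyl at this place, such as an ethyl group, a trifluoromethyl group, an amine or a carboxylic acid, would be accepted, and whether compound 2 and compound 3 would still match at concentrations other than the single one tested.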